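Swapping the isoquinolin-4-yl cap of compound 1

A few compounds are considered here, and "the series" means these few. Any claim that something is new, unique, unknown or untested is made for them only; others in the source may bear on it.

Measured so far in an assay on isolated protein for inhibition of Fatty-acid amide hydrolase 1 (Rattus norvegicus), with a stated time of 60 min; a lower number here means a stronger inhibitor, a higher number a weaker inhibitor:
compound 1 `O=C(Nc1cncc2ccccc12)N1CCN(Cc2cccc(Oc3ccc(Cl)cc3)c2)CC1` gives 8.3 nM
compound 2 `O=C(Nc1noc2ccncc12)N1CCN(Cc2cccc(Oc3ccc(Cl)cc3)c2)CC1` gives 2200 nM
compound 3 `O=C(Nc1ccc2nccn2c1)N1CCN(Cc2cccc(Oc3ccc(Cl)cc3)c2)CC1` gives 3600 nM

Compound 1 has the lowest number of the three, and since its steps to both others lie beyond the scatter it is the strongest inhibitor here. Compound 4 `O=C(Nc1cccc2nccn12)N1CCN(Cc2cccc(Oc3ccc(Cl)cc3)c2)CC1` differs from compound 1 in one place: a group of 9 heavy atoms (7 carbon, 2 nitrogen; one five-membered aromatic ring with 2 hetero atoms, one six-membered aromatic ring with 1 hetero atom) in place of a group of 10 heavy atoms (9 carbon, 1 nitrogen; one six-membered aromatic ring of carbon only, one six-membered aromatic ring with 1 hetero atom), on an amide-type nitrogen. Two measured steps also replace the isoquinolin-4-yl group with a different two-ring aromatic group, and both lost strongly: a 270-fold higher number from compound 1 to compound 2 (2.42 log units; beyond the scatter) and a 430-fold higher number from compound 1 to compound 3 (2.64 log units; beyond the scatter). Between those two replacements the gap was small: a 1.6-fold higher number from compound 2 to compound 3 (0.21 log units; within the scatter). A loss of similar size is therefore expected for compound 4 in this assay, a 300-fold higher number from compound 1 to compound 4 (2.48 log units; beyond the scatter). Compound 4 is estimated at 2500 nM, with a range from 500 nM to 12000 nM.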

Compound 4, half-maximal inhibitory concentration: 5.7 nM
Compound 4: middle estimate off by 440-fold (2.64 log units), on the high side, outside the stated range (below it).
By their numbers in this assay, from the lowest: compounds 4 and 1 (each within the scatter of the next); then compounds 2 and 3 (each within the scatter of the next).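

Replacing isoquinolin-4-yl on the amide-type nitrogen with a group holding a five-membered aromatic ring need not cost activity, as the step stays within the scatter: a 1.5-fold lower number from compound 1 to compound 4 (0.16 log units; within the scatter). Groups with the same ring types can still differ sharply, as in a 630-fold lower number from compound 3 to compound 4 (2.80 log units; beyond the scatter) and a 390-fold lower number from compound 2 to compound 4 (2.59 log units; beyond the scatter). Ring types and heavy-atom count therefore do not alone set the number here, since compound 3 and compound 4 match in both.

Nothing available explains this large gap. As far as these compounds go, how an amine or a carboxylic acid on the new group of compound 4 would change the number also remains open.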